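The source may report more compounds than this note shows. Statements on the series, on what has been measured and on what is new or still open speak of the compounds shown alone.

Measured so far in an ADME assay for permeability, using PAMPA, at pH 4; on this read-out lower numbers stand for lower permeability and higher numbers for higher permeability:
compound 1 `Cc1[nH]c2ccccc2c(=O)c1Cc1ccccc1` gives 110 10^-6 cm/s;
compound 2 `COc1ccc2c(=O)c(Cc3ccccc3)c(C)[nH]c2c1` gives 200 10^-6 cm/s;
compound 3 `Cc1[nH]c2cc(Cl)ccc2c(=O)c1Cc1ccccc1` gives 341 10^-6 cm/s.

On these numbers compound 2 sits in the middle of the three, and both gaps to it fall within the scatter: a 1.8-fold higher number from compound 1 to compound 2 (0.26 log units; within the scatter) and a 1.7-fold higher number from compound 2 to compound 3 (0.23 log units; within the scatter). For the measured compounds named here, the only step beyond the scatter is a 3.1-fold higher number from compound 1 to compound 3 (0.49 log units; beyond the scatter). Compound 4 `COc1ccc2c(=O)c(Cc3ccccc3)c(C)n(C)c2c1` differs from compound 2 by methyl in place of hydrogen on an aromatic nitrogen. Going by the values given here, none of the measured steps bears on this change: each of them exchanges a substituent on an aromatic carbon, and the ring nitrogen carries hydrogen in all three measured compounds. With no guide to direction, the expected step of a 1.3-fold higher number from compound 2 to compound 4 (0.10 log units; within the scatter) is taken to lie within the scatter. The estimate for compound 4 is 250 10^-6 cm/s, ranging from 120 10^-6 cm/s to 500 10^-6 cm/s.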

Compound 4, apparent permeability in the ADME assay: 432 10^-6 cm/s
Compound 4: the middle estimate sits 1.7-fold (0.24 log units) below what was measured; the range from low to high includes it.
By their numbers in the ADME assay, from the lowest: compounds 1, 2, 3 and 4 (each within the scatter of the next, the first and the last beyond it).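

For the compounds shown here, in the ADME assay, methyl in place of hydrogen on the aromatic nitrogen gives a 2.2-fold higher number from compound 2 to compound 4 (0.33 log units; beyond the scatter), the first measured change at this nitrogen, which carries hydrogen in compounds 1, 2 and 3. In a physicochemical assay for solubility, read by HPLC, at pH 7.4 (on this read-out higher numbers stand for higher solubility and lower numbers for lower solubility), the same change gives an at least 4.0-fold higher number from compound 2 to compound 4 (0.60 log units; beyond the scatter). In the physicochemical assay compound 2 gives 5000 nM. In the physicochemical assay compound 4 gives > 20000 nM, a limit of the assay and not a number.

This rests on a single pair of compounds. Going by these compounds, it remains open how a longer chain, such as ethyl, or an amine-bearing chain on this nitrogen would read, and whether methyl there gives a similar step with chloro on the aromatic carbon, as in compound 3.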